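Swapping methyl for bromo on a weak compound

The source may report more compounds than this note shows. Statements on the series, on what has been measured and on what is new or still open speak of the compounds shown alone.

- compound 1 `Cc1ccc(-c2nnc(SCCCN3CCN(c4nc5ccccc5o4)CC3)o2)cc1` gives 100000 nM
- compound 2 `Fc1ccc(-c2nnc(SCCCN3CCN(c4nc5ccccc5o4)CC3)o2)cc1` gives 136000 nM
- compound 3 `Cc1ccc(-c2nnc(SCCCN3CCN(c4nc5ccccc5s4)CC3)o2)cc1` gives 61600 nM

In a functional assay on A-431 cells (Homo sapiens) for inhibition, read by MTT assay, with a stated time of 72 h (on this read-out lower numbers stand for stronger inhibition and higher numbers for weaker inhibition), compound 3 gives 61600 nM and so has a lower number than compound 2, but it stays close to its other neighbour: a 1.6-fold lower number from compound 1 to compound 3 (0.21 log units; within the scatter). Compound 4 `Brc1ccc(-c2nnc(SCCCN3CCN(c4nc5ccccc5s4)CC3)o2)cc1` changes one group: bromo in place of methyl on an aromatic carbon. For the measured compounds named here, no bromo compound has been measured, so the nearest evidence is a methyl swapped for fluoro: a 1.4-fold higher number from compound 1 to compound 2 (0.13 log units; within the scatter). That single step gives no reason to expect a change beyond the scatter in this assay. The expected step is a 1.1-fold higher number from compound 3 to compound 4 (0.04 log units; within the scatter). For compound 4 the estimated value is 68000 nM, with an expected range from 32000 nM to 140000 nM.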

Compound 4, half-maximal inhibitory concentration: 51600 nM
For compound 4 the middle estimate is 1.3-fold (0.12 log units) above the measured one, and the stated range covers the measured number.
By their numbers in this assay, from the lowest: compounds 4, 3, 1 and 2 (each within the scatter of the next, the first and the last beyond it).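

In this assay, 4-bromophenyl in place of 4-methylphenyl gives a 1.2-fold lower number from compound 3 to compound 4 (0.08 log units; within the scatter), so a bromine at this position does not move the number beyond the scatter. Together with the fluoro swap on the compound 1 scaffold, this means two different halogens have now replaced methyl here, on two related compounds, with no clear effect. Nothing measured explains why this swap matters so little.

Methyl, fluoro and bromo are the only groups shown at this position, so an amine or a carboxylic acid here could still behave differently. On these data alone, whether a longer chain elsewhere in the shared core would do more also remains open.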